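A chloro-to-fluoro exchange in an antiproliferative series

The source may hold more compounds than are shown below. What is called first, only, known or untested is meant among the compounds shown, and "the series" means these compounds.

Compound 1 `Nc1nc(N)c2cc(CSC(=S)N3CCN(C4CCCCC4)CC3)ccc2n1`: 4710 nM
Compound 2 `Nc1nc(N)c2cc(CSC(=S)N3CCN(c4ccc(Cl)cc4)CC3)ccc2n1`: 5210 nM

In a functional assay on A549 cells (Homo sapiens) for antiproliferative activity, read by MTT assay, with a stated time of 72 h (on this read-out higher numbers stand for weaker inhibition and lower numbers for stronger inhibition), compound 2 gives 5210 nM, which lies within the scatter of compound 1. Compound 3 `Nc1nc(N)c2cc(CSC(=S)N3CCN(c4ccc(F)cc4)CC3)ccc2n1` has fluoro in place of chloro on an aromatic carbon, para to a large group, turning 4-chlorophenyl into 4-fluorophenyl: fluoro in place of chloro on an aromatic carbon. Within the data shown here, only one measured step bears on this change: a 1.1-fold higher number from compound 1 to compound 2 (0.04 log units; within the scatter). That step replaced cyclohexyl with 4-chlorophenyl on the same ring nitrogen and stayed within the scatter. Among the measured compounds shown here, it is a single step, and no fluoro compound has yet been measured, so the evidence is thin. No shift beyond the scatter is therefore expected in this assay. The expected step is a 1.0-fold lower number from compound 2 to compound 3 (0.02 log units; within the scatter). Compound 3 is estimated at 5000 nM, with an expected range of 2500 nM to 10000 nM.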

Compound 3, half-maximal inhibitory concentration: 2040 nM
For compound 3 the middle estimate is 2.5-fold (0.39 log units) above the measured one; the whole stated range lies above it.
By their numbers in this assay, from the lowest: compound 3; then compounds 1 and 2 (each within the scatter of the next).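

In this assay, among these compounds, the aromatic carbon para to a large group proves sensitive to which halogen it carries: fluoro in place of chloro gives (a 2.6-fold lower number from compound 2 to compound 3 (0.41 log units; beyond the scatter)), the first step beyond the scatter in this set. The aryl group on the ring nitrogen also reads differently now, since 4-chlorophenyl stayed within the scatter of cyclohexyl, whereas 4-fluorophenyl in the same place gives (a 2.3-fold lower number from compound 1 to compound 3 (0.36 log units; beyond the scatter)), which makes compound 3 the most potent of the three. Nothing available here accounts for this shift.

The compounds shown leave open whether the gain comes with fluoro itself or with the loss of chloro, as they do not show how a plain phenyl would compare. They also leave open how a methoxy or a nitrile on the same carbon would read.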